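Pyrrolidin-2-yl to Isopropyl: Expected Cytotoxicity of Compound 3

The source may report more compounds than this note shows. Statements on the series, on what has been measured and on what is new or still open speak of the compounds shown alone.

Compound 1, `O=C(CCC1CCNCC1)Nc1nc2ccc(C(=O)c3ccccc3)cc2[nH]1`: > 30000 nM
Compound 2, `Nc1nc2ccc(C(=O)c3ccccc3)cc2n1C[C@H]1CCCN1`: > 30000 nM

In an ADME assay on HL-60 cells (Homo sapiens) for cytotoxicity, read by resazurin assay, with a stated time of 72 h (on this read-out lower numbers stand for an effect already at smaller amounts and higher numbers for an effect only at larger amounts of compound), compound 1 reaches only a limit of the assay, > 30000 nM. Compound 2 likewise reports only a limit, > 30000 nM. Both values shown therefore sit at the same limit, so compound 2 stands level with compound 1 on the numbers known (the limit of > 30000 nM in this assay, at which 2 of the 2 values shown sit). Compound 3, `CC(C)Cn1c(N)nc2ccc(C(=O)c3ccccc3)cc21`, differs from compound 2 by isopropyl in place of pyrrolidin-2-yl on a saturated chain carbon bound to an aromatic nitrogen. Going by the values given here, no measured pair isolates this change, so the step from compound 2 to compound 3 is expected to stay within the scatter, a step that the limit leaves unreadable from compound 2 to compound 3. Compound 3 is therefore expected at 40000 nM, in the range 12000 nM to 120000 nM, most likely again as a limit.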

Compound 3, half-maximal effective concentration: > 30000 nM
Compound 3: a limit, no number; the forecaster's own chance of this, stated with the estimate: 75%; the middle value is on the limit's open side.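

Going by these compounds alone, compound 2 and compound 3 both give only a limit, so no step between them can be read: the limit of > 30000 nM in this assay, at which 3 of the 3 values shown sit. The compounds shown leave open whether isopropyl in place of pyrrolidin-2-yl changes cytotoxicity at all, and what concentration would produce a half-maximal effect for any of them.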